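Benzylamine ring variation on the shared styryl core

A few compounds are considered here, and "the series" means these few. Any claim that something is new, unique, unknown or untested is made for them only; others in the source may bear on it.

Among the measured compounds shown here, compound 2 `COc1cc(/C=C/c2nc(NCc3ccc(Cl)cc3)c3sccc3n2)cc(OC)c1OC` gives 9050 nM in a functional assay on RAW264.7 cells (Mus musculus) for inhibition, read by Griess assay, with stated times of 1 h and 24 h (a higher number here means a weaker inhibitor, a lower number a stronger inhibitor), the highest of the two numbers so far. Its nearest neighbour is compound 1 `COc1cc(/C=C/c2nc(NCc3ccc(C)cc3)c3sccc3n2)cc(OC)c1OC`, which gives 1860 nM in this assay; the step of a 4.9-fold higher number from compound 1 to compound 2 (0.69 log units; beyond the scatter) came from a chloro in place of a methyl on an aromatic carbon, and compound 2 is therefore the weaker of the two beyond the scatter. Compound 3 `COc1cc(/C=C/c2nc(NCc3ccncc3)c3sccc3n2)cc(OC)c1OC` is not yet measured. It differs from compound 2 by pyridin-4-yl in place of 4-chlorophenyl on a saturated chain carbon bound to a nitrogen on an aromatic ring. For the measured compounds named here, no measured step bears directly on this change: the only step in hand swaps one substituent on the benzyl ring, not the ring itself, so it gives no direction for a ring replacement. For compound 3 a number close to that of compound 2 is expected, with a wide range in either direction. The expected step is a 1.1-fold lower number from compound 2 to compound 3 (0.05 log units; within the scatter). The estimate for compound 3 is 8000 nM, from 2000 nM to 40000 nM.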

Compound 3, half-maximal inhibitory concentration: 6350 nM
Beside the measured number, compound 3's estimate is 1.3-fold (0.10 log units) above it, and the stated range covers the measured number.
By their numbers in this assay, from the lowest: compound 1; then compounds 3 and 2 (each within the scatter of the next).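

In this assay, pyridin-4-yl in place of 4-chlorophenyl on this saturated chain carbon leaves the two numbers within the scatter (a 1.4-fold lower number from compound 2 to compound 3 (0.15 log units; within the scatter)), so this first exchange of the ring itself, bringing a hetero atom and a hydrogen-bond acceptor, cannot be told apart from the chloro compound. Set against the 4-methylphenyl group, the same ring gives a step beyond the scatter (a 3.4-fold higher number from compound 1 to compound 3 (0.53 log units; beyond the scatter)), which leaves compound 1 alone at the low end of the three numbers. No measurement in hand accounts for either step.

Open, as far as these compounds go, is whether a methoxy group or an amine in place of the methyl would stay with compound 1 or fall with compounds 2 and 3. Also open, from the compounds shown here alone, is how a longer chain between the ring and the nitrogen would read in this assay.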